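The compounds below may be only part of what the source reports. "The series", "measured", "known", "first", "only" and "open" are said of these compounds alone.

Compound 1: `CCc1ccc2[nH]c(=O)c(CN(Cc3ccc(F)cc3)Cc3ccc(C(C)(C)C)cc3)cc2c1` — in a toxicity assay on MDCK cells (Canis lupus familiaris) for cytotoxicity, read by crystal violet staining, with a stated time of 48 h (a higher number here means that more compound is tolerated, a lower number that less compound is tolerated), compound 1 gives > 33000 nM, a limit.
Compound 2: `Cc1ccc2[nH]c(=O)c(CN(CCCO)Cc3ccc(C(C)(C)C)cc3)cc2c1` — in this assay compound 2 gives > 10000 nM, also a limit.

Among the compounds with values here, compound 2 therefore stands only at a limit, as does the one other value shown, which sits at the limit of > 33000 nM in this assay, at which 1 of the 2 values shown sits. Compound 3, `CCc1ccc2[nH]c(=O)c(CN(CCCO)Cc3ccc(C(C)(C)C)cc3)cc2c1`, differs from compound 2 by methyl in place of hydrogen on a saturated chain carbon bound to an aromatic carbon, read one bond further out as methyl to ethyl. With both measured values at limits, no step beyond the scatter is expected in this assay. Compound 3 is expected to give about 30000 nM, between 10000 nM and 100000 nM, most likely again reported as a limit. The expected step from compound 2 to compound 3 is a step that the limit leaves unreadable from compound 2 to compound 3.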

Compound 3, half-maximal cytotoxic concentration: > 10000 nM
Compound 3: no number, only a limit; the forecaster's own chance of this, stated with the estimate: 85%; the middle value lies beyond the limit too.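

Compound 1, compound 2 and compound 3 all stand only at limits in this assay, so neither step to compound 3 can be read. The compounds shown leave open at what concentration any of them becomes toxic to these cells.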